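The compounds below may be only part of what the source reports. "The series", "measured", "known", "first", "only" and "open" are said of these compounds alone.

In a functional assay on MCF7 cells (Homo sapiens) for antiproliferative activity, read by colorimetric assay and sulforhodamine B assay, with a stated time of 3 days (on this read-out lower numbers stand for stronger inhibition and higher numbers for weaker inhibition), three compounds have been measured:

Compound 1, `Clc1ncnc2c1ncn2CC1COc2ccccc2S1`: compound 1 gives 10600 nM.
Compound 2, `Clc1nc(Cl)c2ncn(CC3COc4ccccc4S3)c2n1`: compound 2 gives 8970 nM.
Compound 3, `Clc1ncnc2c1ncn2CC1COc2ccccc2O1`: compound 3 gives 18800 nM.

Compound 1 and compound 2 share one core, and compound 2 differs from it only by chloro in place of hydrogen on an aromatic carbon. That change made a step of a 1.2-fold lower number from compound 1 to compound 2 (0.07 log units; within the scatter), so the two numbers cannot be told apart. Compound 3 is built on another core; the difference between the two cores is not broken down here. Compound 4, `Clc1nc(Cl)c2ncn(CC3COc4ccccc4O3)c2n1`, stands to compound 3 as compound 2 stands to compound 1: it carries chloro in place of hydrogen on an aromatic carbon, the same change in the same surroundings, so the two steps can be set side by side. Going by the values given here, the one earlier example of this change gave no clear movement, and the two cores cannot be compared in any counted way, so the only guide is that single step. For compound 4 the expected step is a 1.3-fold lower number from compound 3 to compound 4 (0.10 log units; within the scatter). This rests on compound 1 and compound 2, where the same change gave a 1.2-fold lower number from compound 1 to compound 2 (0.07 log units; within the scatter). Compound 4 is therefore expected to give about 15000 nM, most likely between 6000 nM and 40000 nM.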

Compound 4, half-maximal inhibitory concentration: 19600 nM
Compound 4: middle estimate off by 1.3-fold (0.12 log units), on the low side, and the stated range covers the measured number.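

In this assay, chloro in place of hydrogen on the second core made a step of a 1.0-fold higher number from compound 3 to compound 4 (0.02 log units; within the scatter), so the two numbers cannot be told apart. Set beside the earlier step, the change behaves alike on both cores: the same change on two cores in this assay, a 1.2-fold lower number (0.07 log units; within the scatter) from compound 1 to compound 2 and a 1.0-fold higher number (0.02 log units; within the scatter) from compound 3 to compound 4, 1.2-fold (0.09 log units) apart, within the scatter of two such steps. This shows that, on these two cores and in this one assay, the change can be carried across with the same result, which is no clear movement, but two steps on two cores make no general rule, and agreement between two steps that barely move does not show that a larger effect would carry over in the same way.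

The compounds shown leave open whether a different group on this aromatic carbon between two ring nitrogen atoms, such as an amine or a longer chain, would move the number at all. They also leave open whether either core would respond in the same way to such a group.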